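The source may report more compounds than this note shows. Statements on the series, on what has been measured and on what is new or still open speak of the compounds shown alone.

Three compounds built on one shared core were tested in a functional assay on DU-145 cells (Homo sapiens) for antiproliferative activity, read by sulforhodamine B assay, with a stated time of 72 h; a higher number here means a weaker inhibitor of growth, a lower number a stronger inhibitor of growth. Compound 1, `Cc1cc(=O)oc2cc(SCc3cccc(C(F)(F)F)c3)ccc12`, carries a trifluoromethyl group on an aromatic carbon; compound 2, `Cc1cc(=O)oc2cc(SCc3cccc(C#N)c3)ccc12`, carries a cyano group in its place; compound 3, `Cc1cccc(CSc2ccc3c(C)cc(=O)oc3c2)c1`, carries a methyl group there. In this assay compound 1 gave only a limit of the assay, > 28500 nM, which is a limit rather than a number. In this assay compound 2 likewise reached only a limit, > 32500 nM. In this assay compound 3 also gave only a limit, > 33700 nM. Compound 3 thus stands at a limit, and the two other values shown are limits as well, so none of the three can be ranked against another. The steps a step that the two limits leave unreadable from compound 1 to compound 2, a step that the two limits leave unreadable from compound 1 to compound 3 and a step that the two limits leave unreadable from compound 2 to compound 3 are all unreadable in size: the limit of > 28500 nM in this assay, at which 1 of the 3 values shown sits, the limit of > 32500 nM in this assay, at which 1 of the 3 values shown sits, and the limit of > 33700 nM in this assay, at which 1 of the 3 values shown sits, show every value sitting at a limit.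

The unmeasured compound 4, `Cc1cc(=O)oc2cc(SCc3cccc(OC(F)(F)F)c3)ccc12`, differs from compound 3 by trifluoromethoxy in place of methyl on an aromatic carbon. Within the data shown here, no measured step offers a readable size or direction, so nothing points toward a change beyond the scatter. Compound 4 is therefore expected to give about 40000 nM in this assay, estimated between 15000 nM and 100000 nM, most likely reported again only as a limit. The estimated step that the limit leaves unreadable from compound 3 to compound 4 is expected to amount to no change beyond the scatter.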

Compound 4, concentration for 50% growth inhibition: 15500 nM
Estimate against measurement, compound 4: 2.6-fold (0.41 log units) above; measured number inside the range.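

In this assay, among these compounds, compound 4 is the only one of the four compounds that gives a number rather than a limit, at 15500 nM, so this place on the aromatic ring, meta to a large group, can carry a change that registers in growth inhibition: the result is an at least 2.1-fold lower number from compound 3 to compound 4 (0.33 log units; beyond the scatter), and likewise an at least 2.0-fold lower number from compound 2 to compound 4 (0.32 log units; beyond the scatter). Set against trifluoromethyl, the same place gives an at least 1.8-fold lower number from compound 1 to compound 4 (0.26 log units; that floor lies within the scatter), so trifluoromethoxy is not shown to differ from trifluoromethyl beyond the usual scatter, although the true gap could be larger. All three steps are only minimum sizes, and the one from trifluoromethyl remains the least settled because compound 1 is held only by a limit: the limit of > 28500 nM in this assay, at which 1 of the 4 values shown sits.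

The steps among compounds 1, 2 and 3 still cannot be read, so the three groups they carry cannot be ranked against one another, and one measured compound cannot show whether the gain belongs to the oxygen link, the three fluorines or the whole trifluoromethoxy group. Also open, from the compounds shown here alone, is how a methoxy group, an amine or a carboxylic acid would behave at this same place, and whether trifluoromethoxy would give a similar number elsewhere on the ring.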